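The source may report more compounds than this note shows. Statements on the series, on what has been measured and on what is new or still open speak of the compounds shown alone.

Of the compounds shown here, three sharing one core have been read in a functional assay on Bel-7402 cells (Homo sapiens) for cytotoxicity, read by MTT assay, with a stated time of 24 h; on this read-out higher numbers stand for weaker inhibition and lower numbers for stronger inhibition. Compound 2 `COC(=O)[C@@H](C)NC(=O)Cn1cc(C2=C(c3c[nH]c4ccccc34)C(=O)N(C)C2=O)c2ccccc21` gives 9340 nM, the lowest number available. Compound 3 `COC(=O)[C@@H](CO)NC(=O)Cn1cc(C2=C(c3c[nH]c4ccccc34)C(=O)N(C)C2=O)c2ccccc21` gives 67200 nM. For compound 1 `COC(=O)[C@H](NC(=O)Cn1cc(C2=C(c3c[nH]c4ccccc34)C(=O)N(C)C2=O)c2ccccc21)[C@@H](C)O` the read-out is only a limit, > 100000 nM.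

Compound 4 `COC(=O)C[C@@H](NC(=O)Cn1cc(C2=C(c3c[nH]c4ccccc34)C(=O)N(C)C2=O)c2ccccc21)C(=O)OC` departs from compound 2 by one change: methoxycarbonyl in place of hydrogen on a saturated chain carbon, two bonds along the chain from an amide-type nitrogen and a carbonyl carbon. In words, this is methoxycarbonyl in place of hydrogen on a saturated chain carbon, two bonds along the chain from an amide-type nitrogen and a carbonyl carbon. The closest measured precedent is hydroxy in place of hydrogen at that same place, which gives a 7.2-fold higher number from compound 2 to compound 3 (0.86 log units; beyond the scatter). Compound 1 points the same way, since methyl in place of its 1-hydroxyethyl gives an at least 10-fold lower number from compound 1 to compound 2 (1.02 log units; beyond the scatter). Among these three compounds, none goes against the trend that compound 2, with the smallest group there, has the lowest number. A rise of modest size is therefore expected, and the estimate is a 3.2-fold higher number from compound 2 to compound 4 (0.51 log units; beyond the scatter). In this assay, compound 4 is expected at 30000 nM, within an estimated range of 9000 nM to 100000 nM.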

Compound 4, half-maximal inhibitory concentration: 9360 nM
The estimate for compound 4 lay 3.2-fold (0.51 log units) above the measured number, within the range that was stated.
By their numbers in this assay, from the lowest: compounds 2 and 4 (each within the scatter of the next); then compound 3. At a limit, above all of these: compound 1.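

At this place, on a saturated chain carbon two bonds along the chain from an amide-type nitrogen and a carbonyl carbon, replacing hydrogen need not raise the number: in this assay methoxycarbonyl in place of hydrogen gives a 1.0-fold higher number from compound 2 to compound 4 (0.00 log units; within the scatter) and so compound 2 no longer stands alone at the low end of the series. For the compounds shown here, the higher numbers of the earlier compounds therefore do not follow from substitution as such: methoxycarbonyl in place of hydroxy gives a 7.2-fold lower number from compound 3 to compound 4 (0.86 log units; beyond the scatter) while (methoxycarbonyl)methyl in place of 1-hydroxyethyl gives an at least 10-fold lower number from compound 1 to compound 4 (1.02 log units; beyond the scatter) as the second such contrast. Compound 1 is read only as a limit of the assay, and that last step rests on it: the limit of > 100000 nM in this assay, at which 1 of the 4 values shown sits.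

Going by these compounds, how a carboxylic acid or an amine at this place would read remains open. So does a longer plain alkyl chain.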